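Adding a Benzyloxycarbonyl Cap to Compound 2

This account rests on a few compounds, and the source may have more. Where it says the series, first, only, none or still open, it means among the compounds named here.

Measured compounds:
compound 1 `O=C(OCc1ccccc1)N1CCN(C(=S)SCc2cn(Cc3ccc(F)cc3)nn2)CC1`: > 128000 nM
compound 2 `S=C(SCc1cn(Cc2ccc(Cl)cc2)nn1)N1CCNCC1`: > 128000 nM

Both measured compounds were tested in a functional assay on PC-3 cells (Homo sapiens) for inhibition, read by MTT assay, with a stated time of 72 h; on this read-out lower numbers stand for stronger inhibition and higher numbers for weaker inhibition. In this assay compound 1 gives > 128000 nM, which is a limit of the assay and not a number. In this assay compound 2 likewise gives > 128000 nM, again a limit rather than a number. Among the measured compounds shown here, compound 2 therefore stands at the limit, and the one further value shown is a limit as well, so no step between measured compounds can be counted.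

Compound 3 `O=C(OCc1ccccc1)N1CCN(C(=S)SCc2cn(Cc3ccc(Cl)cc3)nn2)CC1` has not yet been measured. It differs from compound 2 in one place: benzyloxycarbonyl in place of hydrogen on an amine nitrogen in a ring. Compound 1 carries the same benzyloxycarbonyl group on the same ring nitrogen and also sits at the limit.

Compound 3 is expected to show no inhibition beyond the scatter, so the step that the limit leaves unreadable from compound 2 to compound 3 is estimated to be essentially none, because the limit of > 128000 nM in this assay, at which 2 of the 2 values shown sit, holds for both measured compounds. The estimate for compound 3 is 160000 nM, with a range from 90000 nM to 400000 nM.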

Compound 3, half-maximal inhibitory concentration: > 128000 nM
Compound 3 gave a limit, no number (the forecaster's own chance of this, stated with the estimate: 85%); the middle value lies beyond the limit too.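

In this assay compound 3 gives > 128000 nM as a limit and not a number. Among the compounds shown here, no step from compound 1 or compound 2 to compound 3 can be read: the limit of > 128000 nM in this assay, at which 3 of the 3 values shown sit.

How strongly any of these compounds inhibits, and whether either change in structure matters, stays open.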